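Propyl-to-butyl on the piperazine side chain of compound 1

A few compounds are considered here, and "the series" means these few. Any claim that something is new, unique, unknown or untested is made for them only; others in the source may bear on it.

Measured compounds:
compound 1 `CCCN1CCN(CCNC(=O)n2c(=O)n(C3CC3)c3ccccc32)CC1` gives 7.46
compound 2 `CC(C)n1c(=O)n(C(=O)NCCN2CCN(C)CC2)c2ccccc21` gives < 6
compound 3 `CCn1c(=O)n(C(=O)NCCN2CCN(C)CC2)c2ccccc21` gives 6.79

All three are compared in a functional assay for antagonist activity at 5-hydroxytryptamine receptor 4 (Cavia porcellus); on this read-out higher numbers stand for higher potency (the scale is a negative logarithm) and lower numbers for lower potency. Compound 2 reaches only a limit of this assay, (the limit of < 6 in this assay, at which 1 of the 3 values shown sits), not a number. Compound 3 and compound 2 differ in one place, (methyl in place of hydrogen on a saturated chain carbon bound to an aromatic nitrogen and a saturated chain carbon), and this change gave a number at least 0.79 log units lower from compound 3 to compound 2 (beyond the scatter). Compound 1 and compound 3 share much of their structure, but the difference between the two cores is not broken down here; their values show compound 1 standing above compound 3 by more than the scatter.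

Compound 4 `CCCCN1CCN(CCNC(=O)n2c(=O)n(C3CC3)c3ccccc32)CC1` is not yet measured. It differs from compound 1 by methyl in place of hydrogen on a saturated chain carbon, three bonds along the chain from an amine nitrogen in a ring. This is the same kind of change as from compound 3 to compound 2, not the same: there the place was a saturated chain carbon bound to an aromatic nitrogen and a saturated chain carbon, here it is a saturated chain carbon three bonds along the chain from an amine nitrogen in a ring. The measured drop from compound 3 to compound 2 belongs to the other place, so its size is not simply carried over. Resting on compound 1 at 7.46 and on the smaller weight given to a number at least 0.79 log units lower from compound 3 to compound 2 (beyond the scatter) at a different place, compound 4 is expected to give 7.3, an estimated step of a number 0.16 log units lower from compound 1 to compound 4 (within the scatter), with the expected range 6.7 to 7.8.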

Compound 4, negative logarithm of the antagonist equilibrium constant: 7.51
The estimate for compound 4 lay 0.21 log units below the measured number, and the stated range covers the measured number.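

In this assay, methyl in place of hydrogen on a saturated chain carbon, three bonds along the chain from an amine nitrogen in a ring, gave a number 0.05 log units higher from compound 1 to compound 4 (within the scatter), so propyl to butyl on the side chain of compound 1 leaves the read-out unchanged within the scatter. Set beside the earlier step, this added methyl does not carry over from one core to the other with a single size: the same change on two cores in this assay, a number at least 0.79 log units lower (beyond the scatter) from compound 3 to compound 2 and a number 0.05 log units higher (within the scatter) from compound 1 to compound 4, at least 0.84 log units apart, beyond the scatter of two such steps. This does not separate the effect of the core from that of the place, the two changes sitting on different chain carbons, and compound 2 gives a limit, not a number: the limit of < 6 in this assay, at which 1 of the 4 values shown sits.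

Still open, as far as these compounds go, is how the same methyl behaves at one fixed place on both cores, which would separate core from place. Also open, from the compounds shown here alone, is how far the side chain of compound 1 extends beyond butyl, whether to a longer chain such as hexyl or to a chain ending in an amine or a carboxylic acid.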